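The source may hold more compounds than are shown below. What is called first, only, known or untested is meant among the compounds shown, and "the series" means these compounds.

Within the data shown here, compound 1 `COc1ccc(-c2ccc3c(NCCCNCc4cccc(OC)c4O)ccnc3c2)cc1` is one of two compounds measured in an ADME assay on HepG2 cells (Homo sapiens) for cytotoxicity, read by luminescence, CellTiter-Glo and ATP content, with a stated time of 72 h; a higher number here means that more compound is needed for the effect, a lower number that less compound is needed; in this assay compound 1 gives 1600 nM. Compound 2 `COc1cccc(CNCCCNc2ccnc3cc(-c4ccccc4)ccc23)c1O` differs from it by a hydrogen in place of methoxy on an aromatic carbon, and in this assay compound 2 gives 3210 nM. The step of a 2.0-fold higher number from compound 1 to compound 2 (0.30 log units; within the scatter) is the only measured one, so compound 2 stands with the highest of the two numbers, its nearest neighbour being compound 1 at a separation that falls within the scatter. Compound 3 `COc1ccccc1Oc1ccc2c(NCCCNCc3cccc(OC)c3O)ccnc2c1` is not yet measured; it differs from compound 2 by 2-methoxyphenoxy in place of phenyl on an aromatic carbon. Among the measured compounds shown here, the single measured step concerns a different change and was within the scatter, so there is no measured guidance for this larger replacement; no step beyond the scatter is expected in this assay. Compound 3 is therefore expected to give about 2800 nM in this assay, between 900 nM and 9000 nM, a step of a 1.1-fold lower number from compound 2 to compound 3 (0.06 log units; within the scatter).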

Compound 3, half-maximal effective concentration: 11200 nM
Compound 3: the middle estimate sits 4.0-fold (0.60 log units) below what was measured, outside the stated range (above it).
By their numbers in this assay, from the lowest: compounds 1 and 2 (each within the scatter of the next); then compound 3.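

Replacing the aryl group at this position can move the result beyond the scatter in this assay: the change to 2-methoxyphenoxy gives a 3.5-fold higher number from compound 2 to compound 3 (0.54 log units; beyond the scatter), and set against the 4-methoxyphenyl group it gives a 7.0-fold higher number from compound 1 to compound 3 (0.85 log units; beyond the scatter). Among these compounds, the earlier compounds showed only that removing the methoxy from the phenyl group left the number within the scatter, so this is the first sign that this position on the shared core responds to a change of substituent, with more compound needed once 2-methoxyphenoxy is present. No evidence at hand accounts for this result.

The three compounds cannot separate the oxygen that links the ring from the methoxy on it, which a plain phenoxy group would do. Going by these compounds, how a morpholine or a carboxylic acid at this position would read also remains open.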